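Ethoxy in place of isopropylamino on a carbonyl carbon

The source may report more compounds than this note shows. Statements on the series, on what has been measured and on what is new or still open speak of the compounds shown alone.

In a functional assay on U-373MG ATCC cells (Homo sapiens) for inhibition, read by MTT assay, with a stated time of 72 h (a lower number here means a stronger inhibitor, a higher number a weaker inhibitor), compound 1 (`CC1(C)CC(NC(=S)NCc2ccccc2)c2cc(F)ccc2O1`) gives 27000 nM and compound 2 (`CC1(C)CC(NC(=S)Nc2ccc([N+](=O)[O-])cc2)c2cc(Br)ccc2O1`) gives 9000 nM, while compound 3 (`CC(C)NC(=O)NC1CC(C)(C)Oc2ccc(Cl)cc21`) gives 62000 nM as the highest number of the three. Compound 3 is therefore the weakest inhibitor so far, and its gaps to both other compounds lie beyond the usual scatter. No two of these compounds differ in only one place, so the data give no direct measure of any single change.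

The next compound to be read is compound 4 (`CCOC(=O)NC1CC(C)(C)Oc2ccc(Cl)cc21`). It carries ethoxy in place of isopropylamino on a carbonyl carbon whose other neighbour is an amide-type nitrogen (ethoxy in place of isopropylamino on a carbonyl carbon), and the rest of compound 3 stays as it is. For the measured compounds named here, no measured step covers this change, so the expectation rests on compound 3 at 62000 nM as its starting point and remains loose. A small move towards a lower number is expected, not beyond the scatter. The expected change is a 1.4-fold lower number from compound 3 to compound 4 (0.14 log units; within the scatter) in this estimate. In this assay compound 4 is estimated at 45000 nM (expected range 17000 nM to 110000 nM).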

Compound 4, half-maximal inhibitory concentration: > 100000 nM
Compound 4 was reported as a limit; the forecaster's own chance of this, stated with the estimate: 15%; at least 2.2-fold (0.34 log units) between middle value and limit.
By their numbers in this assay, from the lowest: compound 2; then compound 1; then compound 3. At a limit, above all of these: compound 4.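

In this assay, compound 4 gives > 100000 nM, which is a limit of the assay and not a number. This gives the series its first comparison of a single change: ethoxy in place of isopropylamino on a carbonyl carbon whose other neighbour is an amide-type nitrogen produces an at least 1.6-fold higher number from compound 3 to compound 4 (0.20 log units; that floor lies within the scatter), so the swap brings no move towards a lower number at this position. Only a floor can be read, and its true size stays unknown because compound 4 sits at a limit: the limit of > 100000 nM in this assay, at which 1 of the 4 values shown sits.

For the compounds shown here, the change removes a hydrogen-bond donor, brings in a hydrogen-bond acceptor and alters the group's heavy atoms all at once, so the single step cannot separate these differences, and the floor alone does not establish a real loss beyond the scatter. Open questions are whether methylamino or cyclohexylamino on the same carbonyl carbon would keep a measurable number in this assay, and whether replacing the carbonyl oxygen with sulfur while keeping isopropylamino would change it.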